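A few compounds are considered here, and "the series" means these few. Any claim that something is new, unique, unknown or untested is made for them only; others in the source may bear on it.

Measured so far:
- compound 2 `Cc1c(S(=O)(=O)N2CC(C(=O)N(C)C3CCN(C)CC3)c3ccccc32)sc2ccc(Cl)cc12`: in a functional assay on CHO cells for antagonist activity at 5-hydroxytryptamine receptor 6 (Homo sapiens), read by FLIPR (a lower number here means a stronger inhibitor, a higher number a weaker inhibitor), compound 2 gives 63.1 nM
- compound 1 `CN1CCC(N(C)C(=O)C2CN(S(=O)(=O)c3cccc4nsnc34)c3ccccc32)CC1`: compound 1 gives 126 nM

Among the measured compounds shown here, compound 2 has the lowest of the two numbers, and its only neighbour is compound 1, with the step of a 2.0-fold lower number from compound 1 to compound 2 (0.30 log units; within the scatter) lying within the scatter. Compound 3 `CN1CCC(N(C)C(=O)C2CN(S(=O)(=O)c3ccccc3)c3ccccc32)CC1` carries phenyl in place of 5-chloro-3-methyl-1-benzothiophen-2-yl on a sulfonyl sulfur. For the measured compounds named here, the one step that bears on this place, a 2.0-fold lower number from compound 1 to compound 2 (0.30 log units; within the scatter), exchanged one bicyclic aryl for another without a change beyond the scatter, so the aryl on the sulfonyl sulfur has so far mattered little. The step to a bare phenyl is larger in what is removed, and a modest rise in the number is expected, a 3.2-fold higher number from compound 2 to compound 3 (0.50 log units; beyond the scatter). Compound 3 is therefore estimated at 200 nM (range 60 nM to 700 nM).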

Compound 3, inhibition constant: 316 nM
Compound 3: the middle estimate sits 1.6-fold (0.20 log units) below what was measured; the measured number falls inside the stated range.
By their numbers in this assay, from the lowest: compounds 2 and 1 (each within the scatter of the next); then compound 3.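

Phenyl on the sulfonyl sulfur separates from both bicyclic aryl groups in this assay: replacing 5-chloro-3-methyl-1-benzothiophen-2-yl gives a 5.0-fold higher number from compound 2 to compound 3 (0.70 log units; beyond the scatter), and replacing the other bicyclic aryl gives a 2.5-fold higher number from compound 1 to compound 3 (0.40 log units; beyond the scatter). The aryl at this place therefore does matter, although the exchange of one bicyclic group for the other stayed within the scatter. Nothing available explains this difference.

As far as these compounds go, whether the second fused ring or the substituents carry the difference remains open. A phenyl bearing chlorine or methyl, or an amine on the phenyl, would test this.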